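Trimming an Allyl Chain in a Cell Growth Inhibitor

The source may report more compounds than this note shows. Statements on the series, on what has been measured and on what is new or still open speak of the compounds shown alone.

Three compounds built on one shared core were tested in a functional assay on SW480 cells (Homo sapiens) for inhibition, read by luminescence and resazurin assay, with a stated time of 3 days; a lower number here means a stronger inhibitor, a higher number a weaker inhibitor. Compound 1 `C=CCNc1nc(NCc2ccc(C(=O)Nc3ccc(F)cc3)cc2)c2ccccc2n1` gives 11000 nM and stands highest of the three numbers. Its nearest neighbour is compound 2 `C=CCNc1nc(NCc2ccc(C(=O)Nc3ccc(F)cc3)cc2)c2cc(C)ccc2n1`, which gives 10000 nM; the two differ by methyl in place of hydrogen on an aromatic carbon, and the step of a 1.1-fold lower number from compound 1 to compound 2 (0.04 log units; within the scatter) lies within the scatter. The furthest is compound 3 `CN1CCN(c2nc(NCc3ccc(NC(=O)c4ccc(F)cc4)cc3)c3ccccc3n2)CC1`, which gives 2500 nM; it differs from compound 1 in more than one place, so its lower number cannot be tied to any single change.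

Compound 4 `CCNc1nc(NCc2ccc(C(=O)Nc3ccc(F)cc3)cc2)c2ccccc2n1` has not yet been measured. It differs from compound 1 by methyl in place of vinyl on a saturated chain carbon bound to a nitrogen on an aromatic ring, so that allylamino becomes ethylamino. Among the measured compounds shown here, none of the measured steps touches the saturated chain carbon bound to a nitrogen on an aromatic ring; the only single-point step, between compound 1 and compound 2, sits elsewhere and was within the scatter. For the measured compounds named here, with no bearing step, and a change only from allyl to ethyl, no movement beyond the scatter is expected in this assay. Compound 4 is therefore estimated at 11000 nM, with a range from 5000 nM to 25000 nM, and the expected step is no change at the digits printed from compound 1 to compound 4 (within the scatter).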

Compound 4, half-maximal inhibitory concentration: 2500 nM
Compound 4: the middle estimate sits 4.4-fold (0.64 log units) above what was measured; the whole stated range lies above it.
By their numbers in this assay, from the lowest: compounds 3 and 4 (each within the scatter of the next); then compounds 2 and 1 (each within the scatter of the next).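

In this assay, among the compounds shown here, the allylamino chain proves to be a place where the number can move: replacing it with ethylamino gives a 4.4-fold lower number from compound 1 to compound 4 (0.64 log units; beyond the scatter) and this step lies beyond the scatter, whereas the only earlier single-place step, a 1.1-fold lower number from compound 1 to compound 2 (0.04 log units; within the scatter), stayed within it. The change itself is small, since a vinyl of two carbons leaves and a methyl of one carbon enters, taking the double bond outside the aromatic rings with it, yet even this trim on a saturated chain carbon bound to a nitrogen on an aromatic ring produces a modest but real shift. Nothing measured here gives a reason for the shift.

Two things change together in this swap, the double bond and the chain length, so the step cannot say which of them counts; a propyl chain, which has no double bond and keeps the carbon count of allyl, would pull them apart. From the compounds shown here alone, whether the trend continues is also open, as a methylamino group or a longer chain such as butylamino could show how far the number follows the size of this group.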